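The compounds below may be only part of what the source reports. "The series", "measured", "known", "first", "only" and "open" are said of these compounds alone.

Among the compounds with values here, compound 3 `CCOc1ccc2c(c1)OC(c1ccccc1)C(c1ccccc1)C2=O` sits at the top of the three numbers so far: in a functional assay (on this read-out lower numbers stand for an effect already at smaller amounts and higher numbers for an effect only at larger amounts of compound), compound 3 gives 877000 nM. Within the data shown here, compound 1 `COc1ccc2c(c1)OC(c1cccc([N+](=O)[O-])c1)C(c1ccccc1)C2=O` gives 130000 nM in this assay, and compound 2 `COc1ccc2c(c1)OC(c1ccc(Cl)cc1)C(c1ccccc1)C2=O` gives 165000 nM; the only single-point step among them, a 1.3-fold higher number from compound 1 to compound 2 (0.10 log units; within the scatter), lies within the scatter. Compound 3 differs from compound 2 in two places at once, so its higher number cannot be assigned to either change on its own. Compound 4 `CCOc1ccc2c(c1)OC(c1ccc([N+](=O)[O-])cc1)C(c1ccccc1)C2=O` is compound 3 with nitro in place of hydrogen on an aromatic carbon. Among the measured compounds shown here, no measured step adds a substituent to an otherwise bare phenyl on the saturated ring carbon; the step from compound 1 to compound 2 shows only that a 3-nitrophenyl and a 4-chlorophenyl give numbers within the scatter of each other. Both of those substituted compounds lie well under compound 3, and on that basis a lower number is expected for compound 4, as a 4.0-fold lower number from compound 3 to compound 4 (0.60 log units; beyond the scatter), with compound 4 estimated at 220000 nM and a range from 70000 nM to 700000 nM.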

Compound 4, half-maximal effective concentration: > 2500000 nM
Compound 4 was reported as a limit (the forecaster's own chance of this, stated with the estimate: 10%); middle value at least 11-fold (1.05 log units) from the limit.
By their numbers in this assay, from the lowest: compounds 1 and 2 (each within the scatter of the next); then compound 3. At a limit, above all of these: compound 4.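

In this assay, going from phenyl to 4-nitrophenyl gives an at least 2.8-fold higher number from compound 3 to compound 4 (0.45 log units; beyond the scatter), the first single-place step shown to lie beyond the scatter. The value of compound 4 is a limit, not a number: the limit of > 2500000 nM in this assay, at which 1 of the 4 values shown sits. Within the data shown here, the only earlier step exchanged one substituted phenyl for another and stayed within the scatter, whereas this one shows that nitro on an aromatic carbon, para to a large group, raises the number when it replaces hydrogen on the bare phenyl.

The compounds shown leave open whether this rise is specific to nitro or would also follow from another group at the same place, such as fluorine or an amine. They also leave open whether the same change would raise the number with methoxy in place of ethoxy on the shared core.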